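Lengthening the Ester Chain: From Compound 2 to Compound 3

The source may report more compounds than this note shows. Statements on the series, on what has been measured and on what is new or still open speak of the compounds shown alone.

Compound 1 `CC(=O)OCc1ccc2oc(=O)c(C(=O)Oc3cccc(Br)c3)cc2c1` gives 21.8% in a functional assay on HT-1080 cells (Homo sapiens), read by transwell migration, with a stated time of 24 h, tested at 1 uM; on this read-out higher numbers stand for a weaker effect at the one concentration tested and lower numbers for a stronger effect.
Compound 2 `CCCCCC(=O)OCc1ccc2oc(=O)c(C(=O)Oc3cccc(Br)c3)cc2c1` gives 59.3% in this assay.

Of these two numbers, compound 2 stands highest, with compound 1 a step lower: a number 37.5 percentage points higher from compound 1 to compound 2 (beyond the scatter). Compound 3 `CCCCCCC(=O)OCc1ccc2oc(=O)c(C(=O)Oc3cccc(Br)c3)cc2c1` differs from compound 2 by methyl in place of hydrogen on a saturated chain carbon, five bonds along the chain from a carbonyl carbon. For the measured compounds named here, only that one measured step bears on this change; it was large, but it put butyl in place of hydrogen, whereas here only a methyl enters. A smaller rise in this assay is therefore expected, perhaps none beyond the scatter. Compound 3 is expected to give about 65%, within 45% to 85%. The expected step is a number 5.7 percentage points higher from compound 2 to compound 3 (within the scatter).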

Compound 3, a percentage reported as activity, at one concentration (the size of the read-out at that concentration, not a potency): 55.6%
The estimate for compound 3 lay 9.4 percentage points above the measured number; the range from low to high includes it.
By their numbers in this assay, from the lowest: compound 1; then compounds 3 and 2 (each within the scatter of the next).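

In this assay the added methyl, on a saturated chain carbon five bonds along the chain from a carbonyl carbon, gives no change that can be told from scatter (a number 3.7 percentage points lower from compound 2 to compound 3 (within the scatter)), so at this length one more carbon does not separate the two compounds. The large step from the shared acetate end remains with pentyl in place of hydrogen (a number 33.8 percentage points higher from compound 1 to compound 3 (beyond the scatter)).

From the compounds shown here alone, how ethyl or propyl in that place would read stays open, as does a longer chain or an amine at the chain end. No measurement here offers an explanation for any of these steps.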